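Removing a Ring Methyl on a Benzoxazole Hydrazone Series

The source may hold more compounds than are shown below. What is called first, only, known or untested is meant among the compounds shown, and "the series" means these compounds.

Three hydrazones built on a shared core were compared in a functional assay on HT-29 cells (Homo sapiens) for antiproliferative activity, read by sulforhodamine B assay; on this read-out higher numbers stand for weaker inhibition and lower numbers for stronger inhibition. Compound 1, `C/C(=N\Nc1nc2ccccc2o1)c1nccnc1C`, gives 2140 nM in this assay. Compound 2, `C/C(=N\Nc1nc2ccccc2o1)c1cnccn1`, gives 340 nM in this assay. Compound 3, `C/C(=N\Nc1nc2ccccc2o1)c1ccc(C)nn1`, gives 6770 nM in this assay, the highest of the three numbers. Compound 1 and compound 3 have the same atoms joined differently; the difference between the two cores is not broken down here.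

The step from compound 1 to compound 2 is hydrogen in place of methyl on an aromatic carbon, and in this assay it gave a 6.3-fold lower number from compound 1 to compound 2 (0.80 log units; beyond the scatter).

Compound 4, `C/C(=N\Nc1nc2ccccc2o1)c1cccnn1`, has not yet been measured in this assay. It differs from compound 3 by hydrogen in place of methyl on an aromatic carbon. Going by the values given here, this is the same kind of change as the one from compound 1 to compound 2, though not the same change: in the first pair the altered carbon is ortho to a large group, whereas in compound 3 and compound 4 it is para to a large group.

Among the compounds with values here, the measured pair is the only guide here. Compound 4 is expected to show a step of a 4.5-fold lower number from compound 3 to compound 4 (0.65 log units; beyond the scatter) in this assay, somewhat smaller than the earlier one because the surroundings of the changed carbon differ and compound 3 starts from 6770 nM. Compound 4 is therefore estimated at 1500 nM in this assay, with a range from 500 nM to 5000 nM.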

Compound 4, half-maximal inhibitory concentration: 2640 nM
Beside the measured number, compound 4's estimate is 1.8-fold (0.25 log units) below it; low and high end bracket the measured number.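

In this assay, hydrogen in place of methyl on an aromatic carbon again lowered the number, with a 2.6-fold lower number from compound 3 to compound 4 (0.41 log units; beyond the scatter), and the two steps cannot be told apart in size: the same change on two cores in this assay, a 6.3-fold lower number (0.80 log units; beyond the scatter) from compound 1 to compound 2 and a 2.6-fold lower number (0.41 log units; beyond the scatter) from compound 3 to compound 4, 2.5-fold (0.39 log units) apart, within the scatter of two such steps. On these two cores the change therefore went the same way, even though in compound 3 and compound 4 the altered carbon is para to a large group, but two pairs cannot show that the step has one fixed size or that it would hold on any further core. Nor does removing the methyl make the cores equal, as pyridazin-3-yl in place of pyrazin-2-yl still gives a 7.8-fold higher number from compound 2 to compound 4 (0.89 log units; beyond the scatter).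

The compounds shown leave open what groups other than methyl and hydrogen would do on this aromatic carbon, for example an ethyl group, a methoxy group or an amine. Also open, from the compounds shown here alone, is whether a longer chain in place of the methyl on the carbon with a double bond to nitrogen would shift the number in this assay.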